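A few compounds are considered here, and "the series" means these few. Any claim that something is new, unique, unknown or untested is made for them only; others in the source may bear on it.

For the measured compounds named here, in a functional assay on MCF7 cells (Homo sapiens) for antiproliferative activity, read by MTT assay (on this read-out higher numbers stand for weaker inhibition and lower numbers for stronger inhibition), compound 1 `COc1ccc([C@@H]2C(Cc3cccs3)C(=O)N2c2cc(OC)c(OC)c(OC)c2)cc1` gives 1640 nM, the higher of the two numbers so far, while compound 2 `COc1ccc([C@@H]2[C@@H](c3cccs3)C(=O)N2c2cc(OC)c(OC)c(OC)c2)cc1O` gives 7 nM, a gap well beyond the scatter. Compound 3 `COc1ccc([C@@H]2C(c3ccsc3)C(=O)N2c2cc(OC)c(OC)c(OC)c2)cc1` keeps the core of compound 1 and changes one group: thiophen-3-yl in place of (thiophen-2-yl)methyl on a saturated ring carbon. Going by the values given here, no measured pair isolates this change, and the data hold no direct step for it. The value of compound 2, 7 nM, shows that much lower numbers occur in this small set. A move to a lower number in this assay is therefore expected, though probably not all the way to the level of compound 2. The expected size is a 16-fold lower number from compound 1 to compound 3 (1.21 log units; beyond the scatter), beyond the scatter. For compound 3 the estimated value is 100 nM, with an expected range from 20 nM to 500 nM.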

Compound 3, half-maximal inhibitory concentration: 60 nM
For compound 3 the middle estimate is 1.7-fold (0.22 log units) above the measured one; the range from low to high includes it.
By their numbers in this assay, from the lowest: compound 2; then compound 3; then compound 1.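

In this assay, the saturated ring carbon of the four-membered ring proves sensitive to what it carries: thiophen-3-yl in place of (thiophen-2-yl)methyl gives a 27-fold lower number from compound 1 to compound 3 (1.44 log units; beyond the scatter), a large step at this position. Both groups hold one five-membered aromatic ring with the same counts of hydrogen-bond donors and acceptors, yet the read-out still moves well beyond the scatter. No measurement at hand accounts for the step.

The step changes the linking carbon and the thiophene attachment point together, so the share of each stays unresolved. Also open, from the compounds shown here alone, is how this ring carbon would respond to a plain phenyl ring, an aminomethyl group or a longer chain such as 2-(thiophen-2-yl)ethyl.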